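Swapping an aryl ether tail for a plain benzyl group

This account rests on a few compounds, and the source may have more. Where it says the series, first, only, none or still open, it means among the compounds named here.

Compound 1 `COc1ccc(OCCCCCN2CCCC(COC(=O)c3ccccc3N3C(=O)CC(C)C3=O)C2)cc1` was tested in an in vitro functional assay on HEK ts201 cells for antagonist activity at Neuronal acetylcholine receptor; alpha4/beta2 (Homo sapiens), read by fluorescence and calcium flux (on this read-out lower numbers stand for stronger inhibition and higher numbers for weaker inhibition), where it gives 14500 nM. Two companions frame it: compound 2 `O=C(OCc1ccccc1-c1ccccc1)C1CCCN(CCCc2ccccc2)C1` gives 17800 nM and compound 3 `COc1ccc(OCCCCCN2CCCC(COC(=O)c3coc4ccccc4c3=O)C2)cc1` gives 10000 nM; all three values lie within the usual scatter of one another, so none can be called stronger or weaker. Compound 4 `CC1CC(=O)N(c2ccccc2C(=O)OCC2CCCN(CCCCCCc3ccccc3)C2)C1=O` has not been measured. It differs from compound 1 in one place: benzyl in place of 4-methoxyphenoxy on a saturated chain carbon, five bonds along the chain from an amine nitrogen in a ring. Going by the values given here, no measured pair shows this change, but compound 2, which also carries only a phenyl-ended chain on the ring amine, sits close to compound 1. For compound 4 the expected step of a 1.0-fold higher number from compound 1 to compound 4 (0.01 log units; within the scatter) is none beyond the scatter. For compound 4 the estimate is 15000 nM, expected to fall between 6000 nM and 40000 nM.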

Compound 4, half-maximal inhibitory concentration: 29500 nM
Estimate against measurement, compound 4: 2.0-fold (0.29 log units) below, within the range that was stated.
By their numbers in this assay, from the lowest: compounds 3, 1, 2 and 4 (each within the scatter of the next, the first and the last beyond it).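

In this assay, going by these compounds alone, placing benzyl where compound 1 carries 4-methoxyphenoxy gives a 2.0-fold higher number from compound 1 to compound 4 (0.31 log units; beyond the scatter), a modest weakening of inhibition and the first change in this set that lies beyond the usual scatter. The chain end therefore has some influence on inhibition here, although both groups end in a six-membered aromatic ring of carbon only and the incoming group lacks the two hydrogen-bond acceptors. Nothing available explains the difference. This rests on a single pair. On these data alone, whether a plain phenoxy group or an amine at the chain end would restore inhibition remains open.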